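The source may hold more compounds than are shown below. What is called first, only, known or untested is meant among the compounds shown, and "the series" means these compounds.

Compound 1 `CNC(=O)Nc1ccc(-c2nc(N3CC4CCC(C3)O4)c3cnn(C(C)C)c3n2)cc1`: > 0.5 h, a limit
Compound 2 `O=C(Nc1ccncc1)Nc1ccc(-c2nc(N3CC4CCC(C3)O4)c3cnn(C4CCC5(CC4)OCCO5)c3n2)cc1`: > 0.5 h, a limit
Compound 3 `CCNC(=O)Nc1ccc(-c2nc(N3CC4CCC(C3)O4)c3cnn(C4CCC5(CC4)OCCO5)c3n2)cc1`: 0.45 h

All three values come from an in vitro ADME assay on microsomes (Mus musculus) for metabolic stability; on this read-out lower numbers stand for a shorter-lived compound and higher numbers for a longer-lived compound. Compound 1 gives > 0.5 h, which is a limit of the assay and not a number. Its exact place on the scale is therefore unknown, and the set as a whole offers little resolution because of the limit of > 0.5 h in this assay, at which 2 of the 3 values shown sit.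

Compound 4 `CNC(=O)Nc1ccc(-c2nc(N3CC4CCC(C3)O4)c3cnn([C@H]4CC[C@@H](O)CC4)c3n2)cc1` differs from compound 1 by one change: 4-hydroxycyclohexyl in place of isopropyl on an aromatic nitrogen. Among the compounds with values here, the only measured step is an at least 1.1-fold lower number from compound 2 to compound 3 (0.04 log units; that floor lies within the scatter). That step concerns an amide-type nitrogen, not the aromatic nitrogen, so it bears on this change only loosely. Within the data shown here, no measured step replaces the group on the aromatic nitrogen. Compound 3 also carries a larger group than isopropyl there, and it gives 0.45 h.

In this assay, no step beyond the scatter is expected, and the estimated step is a step that the limit leaves unreadable from compound 1 to compound 4. For compound 4 the expected half-life is 0.6 h, with an estimated range of 0.3 h to 1.2 h.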

Compound 4, half-life: > 0.5 h
Compound 4 was reported as a limit (the forecaster's own chance of this, stated with the estimate: 45%); the middle value lies beyond the limit too.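

Compound 1 and compound 4 are both reported only as limits in this assay and not as numbers, so no step can be read between them, because of this: the limit of > 0.5 h in this assay, at which 3 of the 4 values shown sit.

The compounds shown leave open how long compound 1 and compound 4 actually last, and whether 4-hydroxycyclohexyl in place of isopropyl on the aromatic nitrogen changes the half-life at all.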